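The compounds below may be only part of what the source reports. "The series", "measured", "known", "first", "only" and "open" are said of these compounds alone.

Measured in an assay on isolated protein for inhibition of leukotriene B4 receptor 1 (Homo sapiens), tested at 10 uM; a higher number here means more inhibition at the concentration tested (going by the name of the read-out), a lower number less inhibition:
- compound 1, `C=CCc1cc(C(C)=O)c(O)cc1OCCCC#N`: 47%
- compound 2, `C=CCc1cc(C(C)=O)c(O)cc1OCCCCC#N`: 92%
- compound 3, `C=CCc1cc(C(C)=O)c(O)cc1OCCCCCCC#N`: 97%

Compound 3 gives the highest of the three numbers in this assay; compound 2 lies close to it, within the scatter, and compound 1 lies far below it, beyond the scatter.

Compound 4, `C=CCc1cc(C(C)=O)c(O)cc1OCCCC`, is not yet measured. It differs from compound 3 as follows: hydrogen in place of 2-cyanoethyl on a saturated chain carbon, four bonds along the chain from an oxygen on an aromatic ring.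

The steps measured so far all lengthen the chain while keeping its nitrile: a number 45 percentage points higher from compound 1 to compound 2 (beyond the scatter) and a number 50 percentage points higher from compound 1 to compound 3 (beyond the scatter), whereas a number 5 percentage points higher from compound 2 to compound 3 (within the scatter). Shortening the chain therefore went with a large loss in this assay between compound 1 and compound 3, while the longer two chains were alike. Going by the values given here, compound 4 has a chain of about the reach of compound 1 but with no nitrile at all; no measured step removes the nitrile, so its effect is unknown. Going by the chain length alone, a loss of the size seen toward compound 1 is expected, with wide uncertainty; the expected step is a number 62 percentage points lower from compound 3 to compound 4 (beyond the scatter). Compound 4 is estimated at 35%, between 10% and 65%.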

Compound 4, a percentage reported as inhibition, at one concentration (the size of the read-out at that concentration, not a potency): 32%
Beside the measured number, compound 4's estimate is 3 percentage points above it, within the range that was stated.
By their numbers in this assay, from the lowest: compound 4; then compound 1; then compounds 2 and 3 (each within the scatter of the next).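

In this assay the series now includes a chain with no nitrile, and the steps that remove the nitrile-bearing end of the longer chains are both large (a number 65 percentage points lower from compound 3 to compound 4 (beyond the scatter); a number 60 percentage points lower from compound 2 to compound 4 (beyond the scatter)). With methyl in place of cyano at the shorter reach, the step is only modest, though beyond the scatter (a number 15 percentage points lower from compound 1 to compound 4 (beyond the scatter)). The nitrile therefore has a measurable link to the number on the short chain, but that link is much smaller than the steps to the two longer nitrile chains.

Still open, on these data alone, is whether chain length alone would restore the high numbers, which a longer chain ending in methyl would test, while a carboxylic acid at the chain end would test another terminal group. No available evidence accounts for these differences.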